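This account rests on a few compounds, and the source may have more. Where it says the series, first, only, none or still open, it means among the compounds named here.

Compound 3 `CNCc1ccc(Cl)c(-c2ccccc2OC)c1` gives 61% in a functional assay on HEK293 cells for agonist activity at 5-hydroxytryptamine receptor 7 (Homo sapiens), read by a luciferase reporter and beta-arrestin recruitment, with a stated time of 22 h (on this read-out lower numbers stand for smaller maximal responses and higher numbers for larger maximal responses), the highest of the three numbers shown, though the gap to compound 1 `COc1ccccc1-c1cc(C2CCNC2)ccc1Cl`, which gives 54%, and to compound 2 `COc1ccccc1-c1cc(C2CCN(C)C2)ccc1Cl`, which gives 51%, lies within the scatter in each case. Compound 4 `CCNCc1ccc(Cl)c(-c2ccccc2OC)c1` has not been measured. It differs from compound 3 by methyl in place of hydrogen on a saturated chain carbon bound to an amine nitrogen. The measured steps that come closest are the small changes around the amine: a number 3 percentage points lower from compound 1 to compound 2 (within the scatter), together with the two exchanges of the amine-bearing group, a number 7 percentage points higher from compound 1 to compound 3 (within the scatter) and a number 10 percentage points higher from compound 2 to compound 3 (within the scatter), all within the scatter. Nothing in these steps points to a larger change when methyl replaces hydrogen on a saturated chain carbon bound to an amine nitrogen. The step expected from this is no change at the digits printed from compound 3 to compound 4 (within the scatter). Compound 4 is therefore estimated at 61%, with a range from 46% to 76%.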

Compound 4, largest response reached (Emax), in percent of the reference or control that the assay uses: "not active" (no number reported)
Compound 4: no number reported, and the estimate cannot be compared.
By their numbers in this assay, from the lowest: compounds 2, 1 and 3 (each within the scatter of the next).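

Among the compounds shown here, compound 4 is reported as not active in this assay, with no number, so no step from compound 3 to compound 4 can be read. The compounds shown leave open what separates compound 4 from compound 3, and no evidence here addresses that.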